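Swapping the nitrile-bearing group in a cathepsin S inhibitor

The compounds below may be only part of what the source reports. "The series", "measured", "known", "first", "only" and "open" are said of these compounds alone.

In an assay on isolated protein for inhibition of cathepsin S (Homo sapiens), read by fluorescence, with a stated time of 20 min (a higher number here means a weaker inhibitor, a lower number a stronger inhibitor), compound 1 `N#CCNC(=O)[C@@H]1CC(F)(F)C[C@H]1C(=O)N1CCOCC1` gives 830 nM, while compound 2 `N#CCNC(=O)[C@@H]1C[C@@H](S(=O)(=O)c2ccccc2Cl)C[C@H]1C(=O)N1CCOCC1` gives 0.5 nM. Compound 3 `CC(C)(C#N)NC(=O)[C@@H]1C[C@@H](S(=O)(=O)c2ccccc2)C[C@H]1C(=O)N1CCOCC1` gives 3 nM in this assay, the second highest of the three numbers: it sits between compound 1 and compound 2, closer to compound 2. Compound 4 `N#CC1(NC(=O)[C@@H]2C[C@@H](S(=O)(=O)c3ccccc3)C[C@H]2C(=O)N2CCOCC2)CC1` is not yet measured. It differs from compound 3 in one place: 1-cyanocyclopropyl in place of 1-cyano-1-methylethyl on an amide-type nitrogen. Going by the values given here, no pair of measured compounds shows this exact change, so its size cannot be read off the data. The expected step from compound 3 to compound 4 is a 1.5-fold lower number from compound 3 to compound 4 (0.18 log units; within the scatter), within the scatter or slightly toward a stronger inhibitor. Compound 4 is therefore estimated at 2 nM, with a range from 0.7 nM to 6 nM.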

Compound 4, half-maximal inhibitory concentration: 0.7 nM
Estimate against measurement, compound 4: 2.9-fold (0.46 log units) above; the measured number falls inside the stated range.
By their numbers in this assay, from the lowest: compounds 2 and 4 (each within the scatter of the next); then compound 3; then compound 1.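

Replacing 1-cyano-1-methylethyl with 1-cyanocyclopropyl on the amide-type nitrogen gives a 4.3-fold lower number from compound 3 to compound 4 (0.63 log units; beyond the scatter) in this assay, a modest step. Both groups hold 5 heavy atoms and one nitrile, so this position responds to a change that adds no heavy atoms and only closes a three-membered ring. Nothing available explains why the number falls. Going by these compounds, it remains open whether the same swap gives a similar step on a core carrying the chlorophenyl sulfonyl group of compound 2. On these data alone, how a cyclobutane ring bearing the nitrile would fare at this nitrogen also remains open.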